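The compounds below may be only part of what the source reports. "The series", "measured", "known", "first", "only" and "open" are said of these compounds alone.

Measured compounds:
- compound 1 `O=C(Nc1ccccn1)c1c(O)c2cccnc2n(-c2ccccc2)c1=O`: 14.6%
- compound 2 `CCCCNC(=O)c1c(O)c2cccnc2n(-c2ccccc2)c1=O`: 20.4%
- compound 3 `CN(C)CCNC(=O)c1c(O)c2cccnc2n(-c2ccccc2)c1=O`: 18.4%

In a functional assay on the whole organism for inhibition, with Rattus norvegicus as the target, read by cytopathic effect and paw edema, at a dose of 100 mg/kg by the oral route (a higher number here means more inhibition at the dose given (going by the name of the read-out), a lower number less inhibition), compound 3 gives 18.4%, a number that sits among the other two without separating from either: a number 2 percentage points lower from compound 2 to compound 3 (within the scatter) and a number 3.8 percentage points higher from compound 1 to compound 3 (within the scatter). Compound 4 `O=C(NN1CCOCC1)c1c(O)c2cccnc2n(-c2ccccc2)c1=O` is the unmeasured partner of compound 3, and the change is morpholin-4-yl in place of 2-(dimethylamino)ethyl on an amide-type nitrogen. Every measured step here swaps the group on the amide-type nitrogen, and none moved the read-out beyond the scatter: a number 5.8 percentage points higher from compound 1 to compound 2 (within the scatter), a number 3.8 percentage points higher from compound 1 to compound 3 (within the scatter), a number 2 percentage points lower from compound 2 to compound 3 (within the scatter). Nothing among these compounds shows a swap of that group doing more, so the step to compound 4 is expected to be small as well, a number 1.4 percentage points lower from compound 3 to compound 4 (within the scatter). Compound 4 is therefore estimated at 17%, within a range from 8% to 27%.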

Compound 4, a percentage reported as inhibition, in the whole organism at one dose (the size of the read-out at that dose, not a potency): -26.2%
Compound 4: middle estimate off by 43.2 percentage points, on the high side; measured number outside the range, below it.
By their numbers in this assay, from the lowest: compound 4; then compounds 1, 3 and 2 (each within the scatter of the next).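

The group on the amide-type nitrogen can matter after all in this assay, since morpholin-4-yl brings a number 44.6 percentage points lower from compound 3 to compound 4 (beyond the scatter) and a number 46.6 percentage points lower from compound 2 to compound 4 (beyond the scatter) and a number 40.8 percentage points lower from compound 1 to compound 4 (beyond the scatter). So this position is not insensitive to change: butyl, pyridin-2-yl and 2-(dimethylamino)ethyl stay within the scatter of one another, while morpholin-4-yl alone separates. Nothing measured here explains the drop.

From the compounds shown here alone, it remains open whether the ring oxygen or the ring itself on that nitrogen goes with the drop. A piperidin-1-yl group or a 2-(morpholin-4-yl)ethyl chain in the same place could separate these two readings.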